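Benzyl ether variation in a trifluoromethylbenzyl piperazine series

A few compounds are considered here, and "the series" means these few. Any claim that something is new, unique, unknown or untested is made for them only; others in the source may bear on it.

Compound 2 `Cc1ccc(COc2ccc(-c3cc(CN4CCN(Cc5ccc(C(F)(F)F)cc5)CC4)no3)cc2)cc1` is one of three measured analogues that share a core and differ only in the group on a saturated chain carbon bound to an oxygen on an aromatic ring. In a functional assay on Huh-7 cells (Homo sapiens) for antiproliferative activity, read by sulforhodamine B assay, with a stated time of 72 h (a higher number here means a weaker inhibitor, a lower number a stronger inhibitor), compound 2 gives 1500 nM, the second highest of the three numbers. Compound 1 `Cc1ccccc1COc1ccc(-c2cc(CN3CCN(Cc4ccc(C(F)(F)F)cc4)CC3)no2)cc1` gives 1200 nM, and the step of a 1.3-fold higher number from compound 1 to compound 2 (0.10 log units; within the scatter) stays within the scatter. Compound 3 `N#Cc1ccccc1COc1ccc(-c2cc(CN3CCN(Cc4ccc(C(F)(F)F)cc4)CC3)no2)cc1` gives 5000 nM, and the step of a 3.3-fold higher number from compound 2 to compound 3 (0.52 log units; beyond the scatter) is beyond the scatter, as is a 4.2-fold higher number from compound 1 to compound 3 (0.62 log units; beyond the scatter).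

Compound 4 `COc1cc(COc2ccc(-c3cc(CN4CCN(Cc5ccc(C(F)(F)F)cc5)CC4)no3)cc2)cc(OC)c1` is not yet measured. Its change from compound 2 is 3,5-dimethoxyphenyl in place of 4-methylphenyl on a saturated chain carbon bound to an oxygen on an aromatic ring. Within the data shown here, no measured step places a methoxy group, or any phenyl carrying two substituents, at this site, so the bearing steps are indirect: a 1.3-fold higher number from compound 1 to compound 2 (0.10 log units; within the scatter) shows that exchanging 2-methylphenyl for 4-methylphenyl changes little, while a 3.3-fold higher number from compound 2 to compound 3 (0.52 log units; beyond the scatter) shows that a different substituent on the same phenyl can raise the number modestly. The expected step for compound 4 is therefore a 1.5-fold higher number from compound 2 to compound 4 (0.17 log units; within the scatter), a modest rise or none beyond the scatter. Compound 4 is estimated at 2200 nM, within 900 nM to 6000 nM.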

Compound 4, half-maximal inhibitory concentration: 1500 nM
Beside the measured number, compound 4's estimate is 1.5-fold (0.17 log units) above it; measured number inside the range.
By their numbers in this assay, from the lowest: compounds 1, 2 and 4 (each within the scatter of the next); then compound 3.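

In this assay the position on a saturated chain carbon bound to an oxygen on an aromatic ring takes a phenyl carrying two substituents without a step beyond the scatter: 3,5-dimethoxyphenyl, with 10 heavy atoms and 2 hydrogen-bond acceptors against 7 and 0 for 4-methylphenyl, gives no change at the digits printed from compound 2 to compound 4 (within the scatter) and also a 1.3-fold higher number from compound 1 to compound 4 (0.10 log units; within the scatter) from the other methylphenyl analogue. The larger group thus joins the two methylphenyl compounds as a third member of one group of numbers, and compound 3 now stands alone among the four, with a 3.3-fold lower number from compound 3 to compound 4 (0.52 log units; beyond the scatter) adding a third step beyond the scatter to those already seen from compound 1 and compound 2. Across these four compounds, heavy-atom count and acceptor count of the entering group do not track the number, and no accompanying measurement offers any explanation for the position of compound 3.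

From the compounds shown here alone, whether that weaker result belongs to the nitrile itself or to where it stands on the phenyl stays open, as 2-cyanophenyl is the only cyanophenyl in the set. Also open, going by these compounds, is how the position responds to an amine or a carboxylic acid on the phenyl, or to a longer chain in place of the single saturated carbon.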